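A few compounds are considered here, and "the series" means these few. Any claim that something is new, unique, unknown or untested is made for them only; others in the source may bear on it.

Of the compounds shown here, two have been tested in a functional assay on A-375 cells (Homo sapiens) for antiproliferative activity, read by MTT assay, with a stated time of 24 h, tested at 0.01 ug/mL (a lower number here means a weaker effect, a higher number a stronger effect of the compound at the concentration tested), so far. Compound 1, `Cc1c(C(=O)Nc2ccc(-c3ccccc3)cc2)nc2ccccc2c1O`, gives -0.11% in this assay. Compound 2, `COc1ccc2nc(C(=O)Nc3ccc(-c4ccccc4)cc3)c(C)c(C(=O)O)c2c1`, gives 0.35% in this assay. For the measured compounds named here, compound 2 stands highest of the two numbers, but its only neighbour, compound 1, lies within the usual scatter of it, so the two cannot be told apart. Compound 3, `Cc1c(C(=O)Nc2ccc(-c3ccccc3)cc2)nc2ccccc2c1C(=O)O`, differs from compound 2 in one place: hydrogen in place of methoxy on an aromatic carbon. Going by the values given here, no step between measured compounds is available that shows what such a change does here, so the expectation rests on the two measured values alone. Because compound 1 at -0.11% and compound 2 at 0.35% both sit close to zero, no step beyond the scatter is expected. Compound 3 is therefore estimated at 0.2%, ranging from -8% to 8%. The expected step, a number 0.2 percentage points lower from compound 2 to compound 3 (within the scatter), stays within the scatter.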

Compound 3, a percentage reported as inhibition, at one concentration (the size of the read-out at that concentration, not a potency): -0.35%
Beside the measured number, compound 3's estimate is 0.6 percentage points above it; the range from low to high includes it.
By their numbers in this assay, from the lowest: compounds 3, 1 and 2 (each within the scatter of the next).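

In this assay, hydrogen in place of methoxy on an aromatic carbon, meta to a fused ring and para to a fused ring, gives a number 0.7 percentage points lower from compound 2 to compound 3 (within the scatter) and so shows that this swap has no readable effect on the read-out at the one concentration tested. Carboxy in place of hydroxy on an aromatic carbon gives a number 0.2 percentage points lower from compound 1 to compound 3 (within the scatter) and so adds a second single-place swap with no readable effect. Nothing available explains either step.

With all three compounds within the scatter of one another, the compounds shown do not reveal whether either place can affect the read-out at all. On these data alone, it remains open whether an amine or a longer alkoxy chain in place of the methoxy, or an ester or a primary amide in place of the carboxy, would give a step beyond the scatter.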